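A few compounds are considered here, and "the series" means these few. Any claim that something is new, unique, unknown or untested is made for them only; others in the source may bear on it.

Measured compounds in this set:
Compound 1, `Oc1ccc(-c2cc(-c3ccccc3F)cc(-c3ccccc3O)n2)cc1`, gives > 50000 nM, which is a limit of the assay rather than a number.
Compound 2, `Oc1ccc(-c2cc(-c3cccc(F)c3)cc(-c3ccccc3O)n2)cc1`, gives > 50000 nM, again a limit.
Compound 3, `Oc1cccc(-c2cc(-c3ccccc3F)cc(-c3cccc(O)c3)n2)c1`, gives 11200 nM.

All three were tested in a functional assay on DU-145 cells (Homo sapiens) for inhibition; on this read-out higher numbers stand for weaker inhibition and lower numbers for stronger inhibition. Going by the values given here, compound 3 supplies the only number; the limit of > 50000 nM in this assay, at which 2 of the 3 values shown sit, is where the other two values sit. Compound 4, `Oc1cccc(-c2cc(-c3cccc(F)c3)cc(-c3cccc(O)c3)n2)c1`, has not yet been measured. It differs from compound 3 by 3-fluorophenyl in place of 2-fluorophenyl on an aromatic carbon. Compound 1 and compound 2 are separated by the same kind of change, (3-fluorophenyl in place of 2-fluorophenyl on an aromatic carbon), but the surroundings differ: in compound 1 the place is meta to a 2-hydroxyphenyl group and meta to a 4-hydroxyphenyl group, while in compound 3 it is meta to two 3-hydroxyphenyl groups. The difference between the two cores is not broken down here. The measured precedent, a step that the two limits leave unreadable from compound 1 to compound 2, gives no readable size. The expected step is therefore small, about a 1.1-fold higher number from compound 3 to compound 4 (0.03 log units; within the scatter), resting on the value of compound 3, 11200 nM. Compound 4 is expected to give roughly 12000 nM in this assay, most likely between 4000 nM and 40000 nM.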

Compound 4, half-maximal inhibitory concentration: 23800 nM
Compound 4: the middle estimate sits 2.0-fold (0.30 log units) below what was measured; the range from low to high includes it.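

In this assay, 3-fluorophenyl in place of 2-fluorophenyl on the core of compound 3 gives a 2.1-fold higher number from compound 3 to compound 4 (0.33 log units; beyond the scatter), so on this core the change weakens inhibition modestly. Going by these compounds alone, that is the only readable instance of the change, which means that it shows neither the size nor the direction of the step carrying over to another core. On the core of compound 1 the same change gives no readable step, with compound 1 and compound 2 both resting on a limit rather than a number: the limit of > 50000 nM in this assay, at which 2 of the 4 values shown sit.

As far as these compounds go, what an amine or a carboxylic acid would do in place of the fluorophenyl group on that aromatic carbon stays open. So does the effect of a methoxy group in place of the hydroxyl on the 3-hydroxyphenyl groups.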